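Chloromethylbenzyl purines against UACC-257: amino for chloro

A few compounds are considered here, and "the series" means these few. Any claim that something is new, unique, unknown or untested is made for them only; others in the source may bear on it.

Measured so far:
compound 1 `ClCc1ccccc1Cn1cnc2c(Cl)nc(Cl)nc21` — 3890 nM
compound 2 `ClCc1ccc(Cn2cnc3nc(Cl)nc(Cl)c32)cc1` — 5490 nM

Two compounds have been run in a functional assay on UACC-257 cells (Homo sapiens) for cytotoxicity, read by sulforhodamine B assay, with a stated time of 48 h; on this read-out higher numbers stand for weaker inhibition of growth and lower numbers for stronger inhibition of growth. Compound 1 gives 3890 nM, the lower of the two numbers. Compound 2 gives 5490 nM; the gap between the two lies within the scatter, so the pair shows no order in this assay.

Compound 3 `Nc1nc(Cl)c2ncn(Cc3ccccc3CCl)c2n1` has not yet been measured. Relative to compound 1 the change is amino in place of chloro on an aromatic carbon, an amino in place of chloro on an aromatic carbon. Going by the values given here, no step between measured compounds informs this change, so nothing in the present numbers sets its size or direction. The working expectation is a modest rise in the number, that is, somewhat weaker inhibition of growth, with a real chance that the step stays within the scatter. The step expected from compound 1 to compound 3 is a 1.5-fold higher number from compound 1 to compound 3 (0.19 log units; within the scatter). For compound 3 in this assay the estimate is 6000 nM, expected to fall between 2500 nM and 15000 nM.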

Compound 3, concentration for total growth inhibition: 38000 nM
Beside the measured number, compound 3's estimate is 6.3-fold (0.80 log units) below it, outside the stated range (above it).
By their numbers in this assay, from the lowest: compounds 1 and 2 (each within the scatter of the next); then compound 3.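

In this assay, going by these compounds alone, amino in place of chloro on the aromatic carbon between two ring nitrogen atoms gives a 9.8-fold higher number from compound 1 to compound 3 (0.99 log units; beyond the scatter), the first step in these notes that lies beyond the scatter, which shows that the number is sensitive to the group at this position. The rest of compound 1 stands unchanged in compound 3, including the remaining chloro group and the chloromethyl group, so the step belongs to this single replacement of one heavy atom, with one hydrogen-bond donor and one hydrogen-bond acceptor entering. No measurement at hand bears on what lies behind the size of this step.

Going by these compounds, whether the step follows from the loss of chloro or the arrival of amino remains open, and methoxy, methylamino or a plain hydrogen on the same carbon would help separate the two. Also open, on these data alone, is whether the same replacement on compound 2 gives a step of similar size, and whether a replacement of the remaining chloro group would give a comparable one.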